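Swapping a 2-chlorobenzyl for a pyridin-2-ylmethyl

The compounds below may be only part of what the source reports. "The series", "measured", "known", "first", "only" and "open" are said of these compounds alone.

Compound 1, built on the shared core as `CCCCNc1nc(N)nc2c1CN(Cc1ccccc1Cl)CC2`, is the starting point. Going by the values given here, in an assay on HEK293 cells for agonist activity at Toll-like receptor 8 (Homo sapiens), read by a luciferase reporter, with a stated time of 6 h (a higher number here means that more compound is needed for the effect, a lower number that less compound is needed), compound 1 gives 0.05 uM, the second highest of the three numbers known. Its nearest neighbour is compound 2, `CCCCNc1nc(N)nc2c1CN(Cc1cccc(OC)c1Cl)CC2`, which in this assay gives 0.04 uM; the step of a 1.3-fold lower number from compound 1 to compound 2 (0.10 log units; within the scatter) is within the scatter. Compound 3, `CCCCNc1nc(N)nc2c1CN(Cc1ccc(C(C)(C)C)cc1)CC2`, stands furthest away: in this assay compound 3 gives 0.66 uM, beyond the scatter from compound 1.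

Compound 4, `CCCCNc1nc(N)nc2c1CN(Cc1ccccn1)CC2`, carries the change (pyridin-2-yl in place of 2-chlorophenyl on a saturated chain carbon bound to an amine nitrogen in a ring). Among the compounds with values here, no measured step matches this exchange: the step from compound 1 to compound 2 adds a methoxy and leaves the 2-chlorophenyl in place, while compound 3 shows only that another change on this benzyl position can move the number a long way. For compound 4 a modest rise in the number, a 3.0-fold higher number from compound 1 to compound 4 (0.48 log units; beyond the scatter), is therefore expected, with wide uncertainty. Compound 4 is estimated at 0.15 uM, within 0.04 uM to 0.6 uM.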

Compound 4, minimum effective concentration: 0.07 uM
Compound 4: middle estimate off by 2.1-fold (0.33 log units), on the high side, within the range that was stated.
By their numbers in this assay, from the lowest: compounds 2, 1 and 4 (each within the scatter of the next); then compound 3.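

In this assay the exchange of 2-chlorophenyl for pyridin-2-yl gives a 1.4-fold higher number from compound 1 to compound 4 (0.15 log units; within the scatter), so on this saturated chain carbon bound to an amine nitrogen in a ring, the aromatic ring itself can be replaced, not only added to as in the methoxy step. The 2-chlorophenyl, with its chlorine and with no hydrogen-bond acceptor, is therefore not needed to hold the number at this level, since pyridin-2-yl, with one hetero atom and one hydrogen-bond acceptor, serves as well in this assay. No measurement given here explains why the two groups read alike. The compounds shown leave open whether pyridin-3-yl or pyridin-4-yl would behave like pyridin-2-yl. They also leave open how a plain phenyl, or a pyridin-2-yl carrying a chlorine or a methoxy, would read.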